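Furan-2-yl in Place of 4-Bromophenyl: Cytotoxicity on Huh-7

A few compounds are considered here, and "the series" means these few. Any claim that something is new, unique, unknown or untested is made for them only; others in the source may bear on it.

Measured compounds:
compound 1 `NC(=S)N1CCCc2c(OCCCCCOc3cccc4ccccc34)cccc21`, > 50000 nM
compound 2 `NC(=S)n1ccc2c(OCCCCCOc3ccc(Cl)cc3)cccc21`, 24700 nM
compound 3 `O=C(NC(=S)N1CCc2c(OCCCCCOc3ccc(Cl)cc3)cccc21)c1ccc(Br)cc1`, 29100 nM

Of the compounds shown here, three have been tested in an ADME assay on Huh-7 cells (Homo sapiens) for cytotoxicity; on this read-out higher numbers stand for lower toxicity in this test and lower numbers for higher toxicity in this test. Compound 1 gives only a limit there, > 50000 nM, which is not a number. Compound 2 gives 24700 nM. Compound 3 gives 29100 nM. The numbers for compound 3 and compound 2 lie within the usual scatter of each other, so neither can be put ahead of the other. Among the three values, (the limit of > 50000 nM in this assay, at which 1 of the 3 values shown sits).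

The next compound, compound 4 `O=C(NC(=S)N1CCc2c(OCCCCCOc3ccc(Cl)cc3)cccc21)c1ccco1`, has not yet been measured in this assay. It differs from compound 3 in one place: furan-2-yl in place of 4-bromophenyl on a carbonyl carbon. Among the compounds with values here, no step between two measured compounds of this set is available to guide the expectation, so the expectation rests on the position of compound 3 alone. The step expected a 1.2-fold higher number from compound 3 to compound 4 (0.08 log units; within the scatter) is small, within the scatter or at most a modest move toward lower toxicity. For compound 4 the estimate is 35000 nM, in the range from 15000 nM to 100000 nM, with a fair chance that this assay again reports only a limit.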

Compound 4, half-maximal cytotoxic concentration: 4620 nM
Compound 4: the middle estimate sits 7.6-fold (0.88 log units) above what was measured, and the stated range ends above it.
By their numbers in this assay, from the lowest: compound 4; then compounds 2 and 3 (each within the scatter of the next). At a limit, above all of these: compound 1.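

In this assay, the group on the carbonyl carbon proves not to be a neutral place for change: furan-2-yl in place of 4-bromophenyl gives a 6.3-fold lower number from compound 3 to compound 4 (0.80 log units; beyond the scatter), a move toward higher toxicity in this test. Within the data shown here, the earlier compounds offered no step between two measured compounds, so this is the first single change that can be read in the set. Among these compounds, it is also only one change, in which a six-membered aromatic ring of carbon only gives way to a five-membered aromatic ring with 1 hetero atom, and the bromine leaves with it.

Nothing shown bears on why the number falls. As far as these compounds go, whether phenyl, thiophen-2-yl or 4-methoxyphenyl on the same carbonyl carbon would read like the 4-bromophenyl or the furan-2-yl group remains open.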